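Adding a Second Methyl to Compound 2

The source may hold more compounds than are shown below. What is called first, only, known or untested is meant among the compounds shown, and "the series" means these compounds.

Of the compounds shown here, three built on a common core have been measured in a functional assay on HT-29 cells (Homo sapiens) for antiproliferative activity, read by sulforhodamine B assay, with a stated time of 48 h; on this read-out higher numbers stand for weaker inhibition and lower numbers for stronger inhibition. Compound 1 `CCCCCc1ccc(NS(=O)(=O)c2ccc(N3CCNC3=O)cc2)cc1` gives 990 nM in this assay. Compound 2 `Cc1ccccc1NS(=O)(=O)c1ccc(N2CCNC2=O)cc1` gives 200 nM. For compound 3 `CC(C)Cc1ccc(NS(=O)(=O)c2ccc(N3CCNC3=O)cc2)cc1` this assay reports only a limit, > 1000 nM. Among the two numbers available, compound 2 stands lowest, and its nearest neighbour, compound 1, sits a step beyond the scatter away. Among the measured compounds shown here, the single step between measured compounds that differ in one place, a number no lower from compound 1 to compound 3 (the limit leaves the size open), runs into that limit (the limit of > 1000 nM in this assay, at which 1 of the 3 values shown sits), so its size cannot be read.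

Compound 4 `Cc1cccc(NS(=O)(=O)c2ccc(N3CCNC3=O)cc2)c1C` differs from compound 2 by methyl in place of hydrogen on an aromatic carbon. No measured step concerns a methyl added to an aromatic carbon; the one step shown concerns a saturated chain and is of unknown size. There is therefore no measured ground for a shift in either direction, and the step of a 1.3-fold higher number from compound 2 to compound 4 (0.10 log units; within the scatter) is expected to stay within the scatter. On that basis compound 4 is estimated to give about 250 nM in this assay, with a range from 100 nM to 700 nM.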

Compound 4, half-maximal inhibitory concentration: 190 nM
Compound 4: middle estimate off by 1.3-fold (0.12 log units), on the high side; the measured number falls inside the stated range.
By their numbers in this assay, from the lowest: compounds 4 and 2 (each within the scatter of the next); then compound 1. At a limit, above all of these: compound 3.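

In this assay, methyl in place of hydrogen on the aromatic carbon ortho to the methyl group, which turns 2-methylphenyl into 2,3-dimethylphenyl, gives a 1.1-fold lower number from compound 2 to compound 4 (0.02 log units; within the scatter). Among the compounds shown here, this is the first readable step on the aromatic ring that carries the sulfonamide nitrogen, and it shows that this position, ortho to a methyl group and meta to a large group, can take this one extra methyl with no change that stands out from the scatter; the only earlier step lay on a saturated chain and could not be read. The compounds shown offer no ground for giving a cause for this result.

On these data alone, what stays open is whether this position would respond in the same way to a group other than methyl, such as a hydroxyl, an amine, a carboxylic acid or a longer chain like propyl, since a single small group says little about the others. As far as these compounds go, it is also open whether a methyl on any other carbon of the 2-methylphenyl ring would leave the number as unmoved as this one does.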